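The source may report more compounds than this note shows. Statements on the series, on what has been measured and on what is new or still open speak of the compounds shown alone.

In a functional assay on HT-29 cells (Homo sapiens) for antiproliferative activity, read by sulforhodamine B assay, with a stated time of 48 h (a higher number here means a weaker inhibitor, a lower number a stronger inhibitor), compound 3 `COc1ccc(NS(=O)(=O)c2ccc(N3CCNC3=O)cc2)cc1` gives 800 nM and compound 1 `CCc1ccc(NS(=O)(=O)c2ccc(N3CCNC3=O)cc2)cc1` gives 660 nM, a pair within the scatter (a 1.2-fold higher number from compound 1 to compound 3 (0.08 log units; within the scatter)), while compound 2 `Cc1ccc(C)c(NS(=O)(=O)c2ccc(N3CCNC3=O)cc2)c1` stands apart at 46 nM. The change under review leads to compound 4 `COc1ccccc1NS(=O)(=O)c1ccc(N2CCNC2=O)cc1`, with 2-methoxyphenyl in place of 4-methoxyphenyl on a sulfonamide nitrogen. Within the data shown here, no measured pair isolates this change. The large steps of a 17-fold higher number from compound 2 to compound 3 (1.24 log units; beyond the scatter) and a 14-fold lower number from compound 1 to compound 2 (1.16 log units; beyond the scatter) show that the group on that nitrogen can matter greatly, so a moderate move to a lower number is expected in this assay, smaller than either step. The expected step is a 2.7-fold lower number from compound 3 to compound 4 (0.43 log units; beyond the scatter). For compound 4 the estimate is 300 nM, with an expected range of 70 nM to 1000 nM.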

Compound 4, half-maximal inhibitory concentration: 550 nM
Compound 4: the middle estimate sits 1.8-fold (0.26 log units) below what was measured; low and high end bracket the measured number.
By their numbers in this assay, from the lowest: compound 2; then compounds 4, 1 and 3 (each within the scatter of the next).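

In this assay, 2-methoxyphenyl in place of 4-methoxyphenyl on the sulfonamide nitrogen gives a step within the scatter: a 1.5-fold lower number from compound 3 to compound 4 (0.16 log units; within the scatter). The 2-methoxyphenyl group also stays within the scatter of 4-ethylphenyl, a 1.2-fold lower number from compound 1 to compound 4 (0.08 log units; within the scatter), but does not reach the 2,5-dimethylphenyl result, a 12-fold higher number from compound 2 to compound 4 (1.08 log units; beyond the scatter). No measurement here accounts for that gap. Still open, from the compounds shown here alone, is whether 2-methylphenyl alone would match 2,5-dimethylphenyl. Also open, going by these compounds, is how 2,5-dimethoxyphenyl would compare, which would test methoxy groups in the two places that the methyl groups occupy.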